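The source may hold more compounds than are shown below. What is called first, only, known or untested is meant among the compounds shown, and "the series" means these compounds.

Among the measured compounds shown here, compound 2 `CN(C(=O)c1ccc(Cl)cc1)c1ccc2[nH]c(-c3n[nH]c4ccccc34)cc2n1` holds the lowest number of the two measured so far: in a functional assay on A549 cells (Homo sapiens) for antiproliferative activity, read by MTT assay, with a stated time of 72 h (a lower number here means a stronger inhibitor, a higher number a weaker inhibitor), compound 2 gives 2220 nM, whereas compound 1 `CN(C(=O)c1ccccc1)c1ccc2[nH]c(-c3n[nH]c4ccccc34)cc2n1` gives 13800 nM. Compound 3 `CN(C(=O)c1ccc([N+](=O)[O-])cc1)c1ccc2[nH]c(-c3n[nH]c4ccccc34)cc2n1` differs from compound 2 by nitro in place of chloro on an aromatic carbon, the wider reading being 4-chlorophenyl to 4-nitrophenyl. For the measured compounds named here, one measured step touches this carbon: a 6.2-fold lower number from compound 1 to compound 2 (0.79 log units; beyond the scatter). Going by the values given here, no step swaps one substituent for another here, so the direction is open; a substituted ring has so far given the lower number, and a step near the scatter is expected, a 1.1-fold higher number from compound 2 to compound 3 (0.05 log units; within the scatter). Compound 3 is therefore estimated at 2500 nM, with a range from 800 nM to 8000 nM.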

Compound 3, half-maximal inhibitory concentration: 34500 nM
For compound 3 the middle estimate is 14-fold (1.14 log units) below the measured one; the measured number lies above the stated range.
By their numbers in this assay, from the lowest: compound 2; then compound 1; then compound 3.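

In this assay, the group on this aromatic carbon sets the direction of the change: nitro in place of chloro gives a 16-fold higher number from compound 2 to compound 3 (1.19 log units; beyond the scatter) and nitro in place of hydrogen gives a 2.5-fold higher number from compound 1 to compound 3 (0.40 log units; beyond the scatter) in the opposite direction from chloro. A substituent here therefore does not lower the number by itself, as compound 3 goes against what compound 2 suggested. No evidence on hand accounts for the gap between chloro and nitro. Where an amine, a methoxy group or a carboxylic acid on this carbon would fall remains open, as does whether fluoro or bromo would track chloro.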